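Oxime ether isomer swap on the shared core

A few compounds are considered here, and "the series" means these few. Any claim that something is new, unique, unknown or untested is made for them only; others in the source may bear on it.

Within the data shown here, compound 1 `Cc1nc(-c2ccccc2NCC2=NCCN2)no1` gives 724 nM in a functional assay for activation of Alpha-1A adrenergic receptor (Homo sapiens), read by calcium flux; a lower number here means that less compound is needed, a higher number that more compound is needed for the effect; compound 2 `CCO/N=C(\C)c1ccccc1NCC1=NCCN1` gives 52.5 nM, the lowest number of the two measured, and the only measured step is a 14-fold lower number from compound 1 to compound 2 (1.14 log units; beyond the scatter). Compound 3 `CC/C(=N\OC)c1ccccc1NCC1=NCCN1` differs from compound 2 by a group of 6 heavy atoms (4 carbon, 1 nitrogen, 1 oxygen; no ring) in place of a group of 6 heavy atoms (4 carbon, 1 nitrogen, 1 oxygen; no ring), on an aromatic carbon. That measured step traded a ring for an open chain; it does not bear on a redistribution of the same atoms within that chain, so no step beyond the scatter is expected. Compound 3 is therefore expected near 60 nM, within 20 nM to 180 nM. The step this estimate implies, a 1.1-fold higher number from compound 2 to compound 3 (0.06 log units; within the scatter), is expected to stay within the scatter.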

Compound 3, half-maximal effective concentration: 3.31 nM
The estimate for compound 3 lay 18-fold (1.26 log units) above the measured number, and the stated range ends above it.
By their numbers in this assay, from the lowest: compound 3; then compound 2; then compound 1.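

In (this assay) the arrangement of atoms within the open chain on the aromatic carbon matters, not only their number: with the same atoms joined differently, the data show a large step (a 16-fold lower number from compound 2 to compound 3 (1.20 log units; beyond the scatter)). Replacing the five-membered aromatic ring of compound 1 with the chain of compound 3 gives the largest step in the series (a 220-fold lower number from compound 1 to compound 3 (2.34 log units; beyond the scatter)). Nothing at hand explains why this rearrangement matters.

From the compounds shown here alone, whether a longer chain on the carbon or on the oxygen of the oxime ether would lower the number further remains open. So does the effect of an amine at this position.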